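A Hydroxy Group Added to a Shared Core

This account rests on a few compounds, and the source may have more. Where it says the series, first, only, none or still open, it means among the compounds named here.

Compound 1 `O=C1c2ccc(O)c(O)c2O[C@@H](c2cccc(O)c2O)[C@@H]1O` gives > 100000 nM in a functional assay on RAW264.7 cells (Rattus norvegicus) for inhibition, with RAW264.7 (Mus musculus) as the target, read by Griess assay, with stated times of 2 h and 16 h (on this read-out higher numbers stand for weaker inhibition and lower numbers for stronger inhibition), which is a limit of the assay and not a number.
Compound 2 `O=C1c2ccc(O)cc2O[C@@H](c2cccc(O)c2O)[C@@H]1O` gives > 100000 nM in this assay, again a limit.
Compound 3 `O=C1c2ccccc2O[C@H](c2cccc(O)c2O)[C@H]1O` gives > 100000 nM in this assay, also a limit.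

All three values sit at the limit of > 100000 nM in this assay, at which 3 of the 3 values shown sit, so none of them is a measured number. The change from compound 2 to compound 1, (hydroxy in place of hydrogen on an aromatic carbon), gives a step that the two limits leave unreadable from compound 2 to compound 1, and its size cannot be read because the limit of > 100000 nM in this assay, at which 3 of the 3 values shown sit, holds both ends. The difference between the core of compound 3 and the core of compound 2 is not broken down here.

Compound 4 `O=C1c2cc(O)ccc2O[C@H](c2cccc(O)c2O)[C@H]1O` is not yet measured. It differs from compound 3 by hydroxy in place of hydrogen on an aromatic carbon. This is the same kind of change as that from compound 2 to compound 1, but not the same: the earlier hydroxy sat ortho to a fused ring, ortho to a hydroxy group and meta to a fused ring, whereas the new one sits meta to a fused ring and para to a fused ring.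

Because compound 1, compound 2 and compound 3 all rest at the limit of > 100000 nM in this assay, at which 3 of the 3 values shown sit, the step that the limit leaves unreadable from compound 3 to compound 4 is expected to stay small. Compound 4 is therefore estimated at 150000 nM, between 50000 nM and 500000 nM, most likely reported only as a limit.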

Compound 4, half-maximal inhibitory concentration: > 100000 nM
Compound 4: a limit, no number; the forecaster's own chance of this, stated with the estimate: 85%; the middle value lies beyond the limit too.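

The step from compound 3 to compound 4 cannot be read, since both compounds stop at a limit of the assay and not at a number: the limit of > 100000 nM in this assay, at which 4 of the 4 values shown sit.

The compounds shown leave open how strongly any of them inhibits in this assay, and whether adding a hydroxy to the shared core changes that inhibition at all.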